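Replacing nitro with sulfamoyl in a small series

This account rests on a few compounds, and the source may have more. Where it says the series, first, only, none or still open, it means among the compounds named here.

compound 1 `C#CCN(Cc1ccc2nc(C)nc(O)c2c1)c1ccccc1`: > 10700 nM (a limit)
compound 2 `C#CCN(Cc1ccc2nc(C)nc(O)c2c1)c1cccc(CO)c1`: > 54000 nM (a limit)
compound 3 `C#CCN(Cc1ccc2nc(C)nc(O)c2c1)c1ccc([N+](=O)[O-])cc1`: 4800 nM

All three compounds were tested in a functional assay on GC3/MTK- cells (Homo sapiens) for inhibition; on this read-out lower numbers stand for stronger inhibition and higher numbers for weaker inhibition. Among the measured compounds shown here, there, compound 3 gives 4800 nM, the only true number in the set. For compound 1 the assay reports only a limit, > 10700 nM. For compound 2 it likewise reports only a limit, > 54000 nM.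

The next structure is compound 4 `C#CCN(Cc1ccc2nc(C)nc(O)c2c1)c1ccc(S(N)(=O)=O)cc1`, which carries sulfamoyl in place of nitro on an aromatic carbon, para to a large group: sulfamoyl in place of nitro on an aromatic carbon.

For the measured compounds named here, two measured steps bear on this change. Nitro in place of hydrogen gave an at least 2.2-fold lower number from compound 1 to compound 3 (0.34 log units; beyond the scatter), at least a modest gain beyond the scatter. Hydroxymethyl in place of hydrogen gave a step that the two limits leave unreadable from compound 1 to compound 2, so it offers no size to build on. Neither step tests sulfamoyl itself, and the data give no direction for exchanging one group for the other.

In this assay, the expected result is therefore no step beyond the scatter, and the expected change is a 1.3-fold higher number from compound 3 to compound 4 (0.10 log units; within the scatter). For compound 4 the estimated value is 6000 nM, with an expected range from 1800 nM to 20000 nM.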

Compound 4, half-maximal inhibitory concentration: > 26000 nM
Compound 4 ended at the assay's limit; the forecaster's own chance of this, stated with the estimate: 25%; at least 4.3-fold (0.63 log units) between middle value and limit.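

In this assay, sulfamoyl in place of nitro on an aromatic carbon, para to a large group, gave an at least 5.4-fold higher number from compound 3 to compound 4 (0.73 log units; beyond the scatter), so at this position the two groups cannot be treated as interchangeable. The earlier compounds shown here showed only that nitro could be told apart from hydrogen here; this result shows that a second group at the same place does not keep what nitro gave, and compound 3 remains the only one of the four with a true number. The value of compound 4 is a limit and not a number: the limit of > 26000 nM in this assay, at which 1 of the 4 values shown sits.

The steps between compounds that both end at a limit cannot be read, so sulfamoyl, hydroxymethyl and hydrogen cannot be ranked against one another. The compounds shown also leave open what separates nitro from sulfamoyl, since sulfamoyl carries a hydrogen-bond donor and a sulfur atom where nitro has neither, and a methylsulfonyl group, a nitrile or a carboxylic acid at this same place would be needed to tell these differences apart.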